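The compounds below may be only part of what the source reports. "The series", "measured", "known", "first", "only" and "open" are said of these compounds alone.

Measured so far:
- Compound 1 `Cc1cc(C)c(S(=O)(=O)N2CCC(N3CCC(C)CC3)CC2)c(C)c1`: 0.03 nM
- Compound 2 `Cc1cc(C)c(S(=O)(=O)N2CCC(N3CCC(C(C)C)CC3)CC2)c(C)c1`: 0.3 nM
- Compound 3 `Cc1cc(C)c(S(=O)(=O)N2CCC(N3CC(C)CC(C)C3)CC2)c(C)c1`: 17 nM

In a functional assay on DLD-1 cells (Homo sapiens) for antiproliferative activity, read by CellTiter-Glo, with a stated time of 72 h (on this read-out lower numbers stand for stronger inhibition and higher numbers for weaker inhibition), compound 3 gives the highest number of the three, that is the weakest inhibition; the nearest is compound 2, and the gap is shown by a 57-fold higher number from compound 2 to compound 3 (1.75 log units; beyond the scatter), while the gap to compound 1 is shown by a 570-fold higher number from compound 1 to compound 3 (2.75 log units; beyond the scatter). Compound 4 `Cc1cc(C)c(S(=O)(=O)N2CCC(N3CCC(C)OC3)CC2)c(C)c1` is not yet measured. It differs from compound 3 in one place: a group of 7 heavy atoms (5 carbon, 1 nitrogen, 1 oxygen; one six-membered non-aromatic ring with 2 hetero atoms) in place of a group of 8 heavy atoms (7 carbon, 1 nitrogen; one six-membered non-aromatic ring with 1 hetero atom), on a saturated ring carbon, a group with no common name. Going by the values given here, none of the measured steps swaps a ring atom, so no step bears on it directly; the steps that come closest are those that change the saturated ring on this carbon, a 570-fold higher number from compound 1 to compound 3 (2.75 log units; beyond the scatter) and a 57-fold higher number from compound 2 to compound 3 (1.75 log units; beyond the scatter), both large, and a 10-fold higher number from compound 1 to compound 2 (1.00 log units; beyond the scatter), modest. They show that this part of the molecule moves this assay strongly, in either direction. Since compound 3 already stands at the weak end, the step of a 2.4-fold higher number from compound 3 to compound 4 (0.37 log units; beyond the scatter) is expected to be modest. For compound 4 an estimate of 40 nM is given, with a range of 4 nM to 400 nM.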

Compound 4, half-maximal inhibitory concentration: 92 nM
The estimate for compound 4 lay 2.3-fold (0.36 log units) below the measured number, and the stated range covers the measured number.
By their numbers in this assay, from the lowest: compound 1; then compound 2; then compound 3; then compound 4.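

In this assay, compound 4 has the highest number of the four, so a group with a ring oxygen gives the weakest inhibition seen at this position, with a 5.4-fold higher number from compound 3 to compound 4 (0.73 log units; beyond the scatter) as a modest further step. The steps of a 310-fold higher number from compound 2 to compound 4 (2.49 log units; beyond the scatter) and a 3100-fold higher number from compound 1 to compound 4 (3.49 log units; beyond the scatter) are both large, and the second is the largest of the set even though the groups in compound 1 and compound 4 have the same heavy-atom count, which shows that this count alone does not set the number. Nothing available here explains these differences.

The change from compound 3 to compound 4 alters the ring atoms and the methyl groups together, leaving the contribution of each unresolved. Also open, as far as these compounds go, is how a morpholine ring, or a piperidine ring bearing a hydroxyl or a carboxylic acid, would read at this position.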